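A few compounds are considered here, and "the series" means these few. Any claim that something is new, unique, unknown or untested is made for them only; others in the source may bear on it.

Measured so far in a functional assay on 786-0 cells (Homo sapiens) for inhibition, read by sulforhodamine B assay, with a stated time of 48 h; a higher number here means a weaker inhibitor of growth, a lower number a stronger inhibitor of growth:
compound 1 `Nc1cc(N)c2nc(-c3ccccc3)c(Oc3ccc(Cl)c(Cl)c3)nc2c1`: 44700 nM
compound 2 `CCOC(=O)[C@H](CCC(=O)O)NC(=O)c1ccc(Sc2nc3cc(N)cc(N)c3nc2-c2ccccc2)cc1`: < 100000 nM
compound 3 `COc1cc(CNc2nc3cc(N)cc(N)c3nc2-c2ccccc2)cc(OC)c1OC`: < 50200 nM

Going by the values given here, compound 1 stands as the only real number among the three; the others are limits. For compound 2 the assay reports only a limit, (the limit of < 100000 nM in this assay, at which 1 of the 3 values shown sits). For compound 3 the assay likewise reports only a limit, (the limit of < 50200 nM in this assay, at which 1 of the 3 values shown sits). Compound 4 `Nc1cc(N)c2nc(-c3ccccc3)c(Sc3ccc(Cl)c(Cl)c3)nc2c1` has not yet been measured. It differs from compound 1 in one place: (3,4-dichlorophenyl)sulfanyl in place of 3,4-dichlorophenoxy on an aromatic carbon. Among the compounds with values here, no step between measured compounds is available to set a scale, and compound 2, which also carries a sulfanyl linkage, gives only a limit. The change is therefore expected to shift this assay by no more than the scatter, with a 1.3-fold lower number from compound 1 to compound 4 (0.11 log units; within the scatter). Compound 4 is estimated at 35000 nM, within a range from 9000 nM to 130000 nM.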

Compound 4, concentration for total growth inhibition: 61700 nM
For compound 4 the middle estimate is 1.8-fold (0.25 log units) below the measured one; measured number inside the range.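

In this assay, putting (3,4-dichlorophenyl)sulfanyl in place of 3,4-dichlorophenoxy on this aromatic carbon gives the first readable step, a 1.4-fold higher number from compound 1 to compound 4 (0.14 log units; within the scatter) and so the two linking atoms cannot be told apart here. Going by these compounds alone, compounds 2 and 3 report only limits, and no step to them can be read. Nothing measured bears on why this step is so small.

From the compounds shown here alone, whether an amine or a longer chain linking the dichlorophenyl ring at this carbon would also leave the number within the scatter stays open. So does the effect of removing either chlorine.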